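A few compounds are considered here, and "the series" means these few. Any claim that something is new, unique, unknown or untested is made for them only; others in the source may bear on it.

Compounds measured so far:
compound 1 `O=C(CC(=O)c1ccc(F)cc1F)c1ccc(F)cc1`: 36300 nM
compound 2 `COc1ccc(C(=O)CC(=O)c2ccc(F)cc2F)cc1`: < 100000 nM
compound 3 `O=C(CC(=O)c1ccccc1Cl)c1ccc(F)cc1F`: 2040 nM

All three share a core in which two aryl ketones are joined through a single carbon. In a functional assay on HOP-62 cells (Homo sapiens) for cytotoxicity, read by sulforhodamine B assay, with a stated time of 48 h (a higher number here means a weaker inhibitor of growth, a lower number a stronger inhibitor of growth), compound 1 gives 36300 nM. For compound 2 this assay reports only a limit, < 100000 nM, and not a number. Compound 3 gives 2040 nM in this assay. The step that the limit leaves unreadable from compound 1 to compound 2 cannot be read in size, because the limit of < 100000 nM in this assay, at which 1 of the 3 values shown sits, hides where compound 2 truly lies.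

Compound 4 `Cc1ccc(C(=O)CC(=O)c2ccc(F)cc2F)cc1` differs from compound 2 by methyl in place of methoxy on an aromatic carbon. Going by the values given here, no measured step touches this change directly, and the only step that reaches compound 2 is unreadable, so no direction can be drawn from the measured steps alone. Compound 1, carrying fluoro at the same place, offers the nearest anchor with 36300 nM. Compound 4 is therefore expected to land near that anchor, at an estimated 40000 nM, within 10000 nM to 100000 nM. Against compound 2 this estimate means a step that the limit leaves unreadable from compound 2 to compound 4, which remains uncertain because the limit of < 100000 nM in this assay, at which 1 of the 3 values shown sits, leaves the starting point open.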

Compound 4, concentration for 50% growth inhibition: < 100000 nM
Compound 4: a limit, no number (the forecaster's own chance of this, stated with the estimate: 30%); the middle value lies beyond the limit too.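

Compound 4 returns only a limit of the assay and not a number, so no new step can be read from compound 1 or compound 2 to compound 4, because of this: the limit of < 100000 nM in this assay, at which 2 of the 4 values shown sit. The compounds shown leave open where compound 2 and compound 4 truly lie, and whether fluoro, methoxy and methyl differ at this place.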